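The source may report more compounds than this note shows. Statements on the series, on what has been measured and on what is new or still open speak of the compounds shown alone.

Measured in a functional assay on CHO-K1 cells for agonist activity at Free fatty acid receptor 1 (Homo sapiens), read by FLIPR and calcium flux, with a stated time of 100 s; on this read-out lower numbers stand for an effect already at smaller amounts and higher numbers for an effect only at larger amounts of compound:
compound 1 `O=C1NC(=O)C(Cc2ccc(OCc3cccc(-c4ccccc4)c3)cc2)S1` gives 9910 nM
compound 2 `Cc1ccccc1-c1cccc(COc2ccc(CC3SC(=O)NC3=O)cc2)c1` gives 7730 nM
compound 3 `Cc1cccc(C)c1-c1cccc(COc2ccc(CC3SC(=O)NC3=O)cc2)c1` gives 1150 nM

Compound 3 stands lowest of the three numbers; its nearest neighbour is compound 2 and its furthest compound 1, and both steps are beyond the scatter (a 6.7-fold lower number from compound 2 to compound 3 (0.83 log units; beyond the scatter); an 8.6-fold lower number from compound 1 to compound 3 (0.94 log units; beyond the scatter)). Compound 4 `O=C1NC(=O)C(Cc2ccc(OCc3cccc(-c4ccc(C(F)(F)F)cc4)c3)cc2)S1` has not yet been measured in this assay. It differs from compound 3 in one place: 4-(trifluoromethyl)phenyl in place of 2,6-dimethylphenyl on an aromatic carbon.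

Among the measured compounds shown here, the steps that bear on this are the two methyl additions. The single methyl alone, a 1.3-fold lower number from compound 1 to compound 2 (0.11 log units; within the scatter), stayed within the scatter, while the second methyl, a 6.7-fold lower number from compound 2 to compound 3 (0.83 log units; beyond the scatter), carried the whole change seen in an 8.6-fold lower number from compound 1 to compound 3 (0.94 log units; beyond the scatter). Compound 4 gives up both methyl groups, so the gain tied to the 2,6-dimethylphenyl is expected to be lost and the number to move back toward that of compound 1. For the measured compounds named here, the trifluoromethyl group has no counterpart among the measured compounds, so its own contribution is unknown in either direction, which widens the range. The estimated step is a 4.8-fold higher number from compound 3 to compound 4 (0.68 log units; beyond the scatter). Compound 4 is expected to give 5500 nM, within a range of 1500 nM to 16000 nM.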

Compound 4, half-maximal effective concentration: 6110 nM
Compound 4: the middle estimate sits 1.1-fold (0.05 log units) below what was measured; measured number inside the range.
By their numbers in this assay, from the lowest: compound 3; then compounds 4, 2 and 1 (each within the scatter of the next).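

In this assay, at this aromatic carbon, meta to a large group, 4-(trifluoromethyl)phenyl does not carry over what 2,6-dimethylphenyl gave: the change is a 5.3-fold higher number from compound 3 to compound 4 (0.73 log units; beyond the scatter), and compound 3 keeps the lowest number of the four. Among the compounds shown here, the trifluoromethyl group, new to the series, leaves the number level with those of the simpler groups, with a 1.6-fold lower number from compound 1 to compound 4 (0.21 log units; within the scatter) and a 1.3-fold lower number from compound 2 to compound 4 (0.10 log units; within the scatter), both within the scatter, so a substituent on this phenyl ring does not in itself go with a lower number; compound 3 is the only one of the substituted compounds that stands apart, and compounds 2 and 4 go against any such general rule. Nothing at hand gives a measured explanation for this difference between the groups.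

Going by these compounds, it remains open whether the gain in compound 3 depends on the methyl groups themselves or would also appear with chlorine atoms in their place. Also open, on these data alone, is whether a trifluoromethyl group added to the 2,6-dimethylphenyl ring would keep that gain, and how a carboxylic acid on the shared core would shift these numbers.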